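Three Values at the Limit and a Fourth Compound Awaited

The source may hold more compounds than are shown below. What is called first, only, known or untested is meant among the compounds shown, and "the series" means these compounds.

Compound 1, `OCCOCn1cnc2cc(Cl)c(Cl)cc21`: > 100000 nM
Compound 2, `OCCOCn1cnc2c(Cl)c(Cl)ccc21`: > 100000 nM
Compound 3, `OCCOCn1c(S)nc2cc(Cl)c(Cl)cc21`: > 100000 nM

In a functional assay on KB cells (Homo sapiens) for inhibition (on this read-out lower numbers stand for stronger inhibition and higher numbers for weaker inhibition), compound 1 gives > 100000 nM, a limit of the assay rather than a number. Compound 2 likewise gives > 100000 nM, again a limit. Compound 3 gives > 100000 nM, also a limit. The difference between the core of compound 1 and the core of compound 2 is not broken down here. Compound 3 arises from compound 1 by sulfanyl in place of hydrogen on an aromatic carbon, and the step that the two limits leave unreadable from compound 1 to compound 3 cannot be read, since (the limit of > 100000 nM in this assay, at which 3 of the 3 values shown sit).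

Compound 4, `OCCOCn1c(S)nc2c(Cl)c(Cl)ccc21`, has not yet been measured. It arises from compound 2 by the same change, (sulfanyl in place of hydrogen on an aromatic carbon). In this assay the step that the limit leaves unreadable from compound 2 to compound 4 is expected to be as unreadable as a step that the two limits leave unreadable from compound 1 to compound 3, resting on the fact that compound 2 sits at > 100000 nM and compound 3 at > 100000 nM. Compound 4 is therefore expected to give about 150000 nM, most likely again only a limit, with a range from 50000 nM to 500000 nM.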

Compound 4, half-maximal inhibitory concentration: > 100000 nM
Compound 4: a limit, no number; the forecaster's own chance of this, stated with the estimate: 85%; the middle value is on the limit's open side.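

In this assay compound 4 gives > 100000 nM, a limit of the assay and not a number. The change from compound 2 to compound 4 therefore yields no readable step: the limit of > 100000 nM in this assay, at which 4 of the 4 values shown sit. The compounds shown leave open whether sulfanyl in place of hydrogen on an aromatic carbon alters inhibition at all, since none of them gives a number.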